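One Ring Substituent Changed: From Compound 3 to Compound 4

The source may report more compounds than this note shows. Statements on the series, on what has been measured and on what is new or still open speak of the compounds shown alone.

Of the compounds shown here, three have been measured in a functional assay on A549 cells (Homo sapiens) for cytotoxicity, read by MTT assay, with a stated time of 72 h; a lower number here means a stronger inhibitor, a higher number a weaker inhibitor. Compound 1 `CNC(=O)c1cc(Oc2ccc(NC(=O)c3nn(-c4ccccc4OC(F)(F)F)c(=O)cc3C)cc2F)ccn1` reaches only a limit, and in this assay compound 1 gives > 40000 nM. Compound 2 `CNC(=O)c1cc(Oc2ccc(NC(=O)c3nn(-c4ccccc4F)c(=O)cc3C)cc2F)ccn1` likewise stops at a limit, and in this assay compound 2 gives > 40000 nM. The step that the two limits leave unreadable from compound 1 to compound 2 therefore cannot be read, as both values sit at the limit of > 40000 nM in this assay, at which 2 of the 3 values shown sit. Among the compounds with values here, compound 3 `Cc1cc(=O)n(-c2ccccc2C(F)(F)F)nc1C(=O)Nc1ccc(Oc2ncnc3ccsc23)cc1` is the only one with a number: in this assay compound 3 gives 8850 nM. Within the data shown here, it is the sole measured number among the three.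

Compound 4 `Cc1cc(=O)n(-c2ccc(F)c(F)c2)nc1C(=O)Nc1ccc(Oc2ncnc3ccsc23)cc1` differs from compound 3 in one place: 3,4-difluorophenyl in place of 2-(trifluoromethyl)phenyl on an aromatic nitrogen. Among the measured compounds shown here, the one measured step, from compound 1 to compound 2, also exchanges fluorinated groups on a phenyl ring on that aromatic nitrogen, but it lies between two limits and has no readable size. For the measured compounds named here, no measured step therefore sets a direction for this change, and nothing beyond the scatter is expected in this assay. Compound 4 is expected to give 12000 nM, within 3000 nM to 40000 nM. The step of a 1.4-fold higher number from compound 3 to compound 4 (0.13 log units; within the scatter) is thus estimated to be small, with a real chance that compound 4 also reports only a limit.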

Compound 4, half-maximal inhibitory concentration: 8180 nM
Compound 4: middle estimate off by 1.5-fold (0.17 log units), on the high side; measured number inside the range.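

In this assay the new pair gives the first readable size for an exchange of fluorinated phenyl groups on this aromatic nitrogen: a 1.1-fold lower number from compound 3 to compound 4 (0.03 log units; within the scatter). On this core, 3,4-difluorophenyl and 2-(trifluoromethyl)phenyl therefore cannot be told apart in this read-out, although the two groups carry their fluorine in different places on the ring. The earlier pair could not show this, as the step from compound 1 to compound 2 cannot be read, both values being limits and not numbers: the limit of > 40000 nM in this assay, at which 2 of the 4 values shown sit.

From the compounds shown here alone, what a phenyl ring carrying an amine or a carboxylic acid would give on this aromatic nitrogen remains open. Within the data shown here, also open is whether any group at this position can move the number beyond the scatter, since the single readable step here stays within it.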